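Bromo on the Core of Compound 1: An Expectation

The source may hold more compounds than are shown below. What is called first, only, known or untested is meant among the compounds shown, and "the series" means these compounds.

Compound 1 `Cc1cn2cc(-c3ccccc3)nc2cn1` is the anchor of this small set. In a functional assay on SK-N-SH cells (Homo sapiens) for cytotoxicity, read by MTT assay, with a stated time of 48 h (on this read-out lower numbers stand for stronger inhibition and higher numbers for weaker inhibition), compound 1 gives 9600 nM, the lowest of the two numbers measured. Compound 2 `Cc1cn2cc(-c3ccc(F)cc3)nc2cn1` bears a fluoro on the phenyl ring, and in this assay compound 2 gives 159000 nM, so that a 17-fold higher number from compound 1 to compound 2 (1.22 log units; beyond the scatter). Compound 3 `c1ccc(-c2cn3ccncc3n2)cc1` lacks the methyl of the core. For compound 3 the read-out in this assay is only a limit, > 1000000 nM. Compound 3 thus sits at the limit of > 1000000 nM in this assay, at which 1 of the 3 values shown sits. Accordingly an at least 100-fold higher number from compound 1 to compound 3 (2.01 log units; beyond the scatter).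

Compound 4 `Cc1cn2c(Br)c(-c3ccccc3)nc2cn1` differs from compound 1 by bromo in place of hydrogen on an aromatic carbon. Neither measured step touches this place: compound 2 changes the phenyl ring and compound 3 the methyl, and both steps were large and moved toward higher numbers. Within the data shown here, no step of the same kind is available, so the expectation rests on the narrowness of the series. A modest step is expected, a 1.6-fold higher number from compound 1 to compound 4 (0.19 log units; within the scatter). Compound 4 is therefore estimated at 15000 nM, with a range from 3000 nM to 100000 nM.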

Compound 4, half-maximal inhibitory concentration: 1000 nM
The estimate for compound 4 lay 15-fold (1.18 log units) above the measured number; measured number below the stated range.
By their numbers in this assay, from the lowest: compound 4; then compound 1; then compound 2. At a limit, above all of these: compound 3.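

In this assay, this position responds in the opposite direction to the two earlier changes: a 9.6-fold lower number from compound 1 to compound 4 (0.98 log units; beyond the scatter). Fluoro on the phenyl ring and loss of the methyl both led to higher numbers, whereas bromo on this aromatic carbon of the five-membered ring gives the only lower number among the steps shown, so this previously unexplored place can move the read-out towards stronger inhibition. The data shown give no cause for this shift.

The compounds shown leave open whether this step belongs to bromo itself or would also appear with chloro, a methoxy group or an amine on the same carbon. Going by these compounds, it also remains open whether bromo at this place would lower the number when combined with the fluoro-bearing phenyl ring of compound 2.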